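This account rests on a few compounds, and the source may have more. Where it says the series, first, only, none or still open, it means among the compounds named here.

In a functional assay on A549 cells (Homo sapiens) for cytotoxicity, read by sulforhodamine B assay, with a stated time of 2 days, tested at 100 uM (on this read-out lower numbers stand for less inhibition and higher numbers for more inhibition at the one concentration tested (going by the name of the read-out)), compound 1 `CCCc1n[nH]c2c(=O)n(NC(=O)c3ccccc3)c(-c3cccc([N+](=O)[O-])c3)nc12` gives 33.2%, a modest effect at the single concentration tested. Compound 2 `O=C(Nn1c(-c2cccc([N+](=O)[O-])c2)nc2c(-c3cccc(Cl)c3)n[nH]c2c1=O)c1ccccc1` carries a 3-chlorophenyl group on the shared core, but in this assay compound 2 gives "not determined" (no result reported), so it stands on no number at all. Compound 3 `O=C(Nn1c(-c2cccc([N+](=O)[O-])c2)nc2c(CCc3ccccc3)n[nH]c2c1=O)c1ccccc1` differs from compound 2 in one place: phenethyl in place of 3-chlorophenyl on an aromatic carbon. Among the measured compounds shown here, with no measured step of this kind to lean on, a change no larger than the ordinary scatter is expected in this assay, in either direction. Compound 3 is therefore estimated at 30%, somewhere between 10% and 55%.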

Compound 3, a percentage reported as inhibition, at one concentration (the size of the read-out at that concentration, not a potency): 73.9%
For compound 3 the middle estimate is 43.9 percentage points below the measured one, outside the stated range (above it).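

Phenyl in place of methyl on a saturated chain carbon, two bonds along the chain from an aromatic carbon, gives a number 40.7 percentage points higher from compound 1 to compound 3 (beyond the scatter) in this assay. This position therefore responds strongly to what its chain carries, which a single measured compound could not show. Nothing measured here explains the size of this step.

Compound 2 has no reported number, so the step from compound 2 to compound 3 cannot be read. As far as these compounds go, whether an amine on the same chain, or a longer chain carrying phenyl, would move the read-out remains open.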